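This account rests on a few compounds, and the source may have more. Where it says the series, first, only, none or still open, it means among the compounds named here.

Measured compounds:
- compound 1, `O=C(O)CCCCCCN1C(=O)CC[C@@H]1CCC(O)Cc1ccccc1`: 32.5 nM
- compound 2, `O=C(O)c1ccc(CCCN2C(=O)CC[C@@H]2CCC(O)Cc2ccc3ccccc3c2)s1`: 500 nM
- compound 3, `O=C(O)CCCCCCN1C(=O)CCC1CCC(O)Cc1cccc(Cl)c1`: 8.8 nM

In a functional assay on HEK293 cells with prostaglandin E2 receptor EP4 subtype (Rattus norvegicus) as the target, read by cAMP accumulation (on this read-out higher numbers stand for an effect only at larger amounts of compound and lower numbers for an effect already at smaller amounts), compound 3 stands at the lowest of the three numbers. Compound 1 comes nearest, with a number that is beyond the scatter, and compound 2 lies furthest away, also beyond the scatter. No two of these compounds differ in only one place, so no single structural step can be read from them; what compound 1 and compound 2 show is only their two values side by side.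

Compound 4, `O=C(O)c1ccc(CCCN2C(=O)CCC2CCC(O)Cc2cccc(Cl)c2)cc1`, differs from compound 3 in one place: 4-carboxyphenyl in place of 3-carboxypropyl on a saturated chain carbon, three bonds along the chain from an amide-type nitrogen in a ring. Going by the values given here, no measured pair isolates this kind of exchange, so the expectation rests on the change alone and is held loosely. The account expects a step in this assay from compound 3 to compound 4 of a 6.8-fold higher number from compound 3 to compound 4 (0.83 log units; beyond the scatter), towards a higher number, and beyond the scatter. For compound 4 the estimated value in this assay is 60 nM, within a range from 15 nM to 250 nM.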

Compound 4, half-maximal effective concentration: 425 nM
The estimate for compound 4 lay 7.1-fold (0.85 log units) below the measured number; the whole stated range lies below it.
By their numbers in this assay, from the lowest: compound 3; then compound 1; then compounds 4 and 2 (each within the scatter of the next).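

In this assay the exchange of 3-carboxypropyl for 4-carboxyphenyl gives the first step that can be read from a single change among these compounds (a 48-fold higher number from compound 3 to compound 4 (1.68 log units; beyond the scatter)), a large move towards a higher number. This position, on a saturated chain carbon, three bonds along the chain from an amide-type nitrogen in a ring, therefore does not accept this change without a clear loss, even though the counts of hydrogen-bond donors and acceptors in the two groups are the same. Nothing available here accounts for the size of this step.

One step cannot separate the effect of the aromatic ring from that of the altered chain. Going by these compounds, how a cyclohexyl ring carrying the carboxylic acid, or a tetrazole in place of the acid, would fare at this position remains open.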